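The source may hold more compounds than are shown below. What is called first, only, known or untested is meant among the compounds shown, and "the series" means these compounds.

Measured compounds:
compound 1, `CCC(C)(C)Cc1c[nH]c(CCc2ccc(-c3cccc(N)n3)cc2)n1`, gives 119 nM
compound 2, `CCC(C)(C)Cc1c[nH]c(CCc2ccc(-c3cnccn3)cc2)n1`, gives 107 nM
compound 3, `CCC(C)(C)Cc1c[nH]c(CCc2ccc(-c3cccc(C)n3)cc2)n1`, gives 106 nM

All three values come from a functional assay on HEK293 cells for agonist activity at Bombesin receptor subtype-3 (Mus musculus), read by luminescence and calcium flux, with a stated time of 10 min; a lower number here means that less compound is needed, a higher number that more compound is needed for the effect. Compound 3 holds the lowest of the three numbers, but its neighbours sit within the scatter of it: the steps are a 1.1-fold lower number from compound 1 to compound 3 (0.05 log units; within the scatter) and a 1.0-fold lower number from compound 2 to compound 3 (0.00 log units; within the scatter), and the remaining pair shows a 1.1-fold lower number from compound 1 to compound 2 (0.05 log units; within the scatter). Across these three compounds, exchanging the group on the aromatic carbon of the shared core has left this assay essentially unchanged.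

Compound 4, `CCC(C)(C)Cc1c[nH]c(CCc2ccc(-c3ccccc3C(=O)O)cc2)n1`, takes the next step from compound 3: 2-carboxyphenyl in place of 6-methylpyridin-2-yl on an aromatic carbon. For the measured compounds named here, none of the measured steps involves a 2-carboxyphenyl group; they only exchanged 6-aminopyridin-2-yl, pyrazin-2-yl and 6-methylpyridin-2-yl, or methyl for amino, among themselves, and each of those was within the scatter. The step to compound 4 is therefore less well anchored by the measured steps, and the range of the estimate is wider. Because the three measured steps, a 1.1-fold lower number from compound 1 to compound 2 (0.05 log units; within the scatter) among them, were all flat, a moderate rise in the number is expected rather than a large one. For compound 4 the expected step is a 2.8-fold higher number from compound 3 to compound 4 (0.45 log units; beyond the scatter). Compound 4 is estimated at 300 nM, with a range from 70 nM to 1500 nM.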

Compound 4, half-maximal effective concentration: 94 nM
Compound 4: the middle estimate sits 3.2-fold (0.50 log units) above what was measured, and the stated range covers the measured number.
By their numbers in this assay, from the lowest: compounds 4, 3, 2 and 1 (each within the scatter of the next).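

For the compounds shown here, at this place, on an aromatic carbon para to a large group, the earlier compounds had only exchanged rings carrying nitrogen, whereas compound 4 brings a six-membered aromatic ring of carbon only, bearing a carboxyl group with a hydrogen-bond donor that the group it replaces lacks. Even so, the reading in this assay stays flat against all three earlier compounds, with a 1.1-fold lower number from compound 3 to compound 4 (0.05 log units; within the scatter), a 1.1-fold lower number from compound 2 to compound 4 (0.06 log units; within the scatter) and a 1.3-fold lower number from compound 1 to compound 4 (0.10 log units; within the scatter), so this position now tolerates a wider range of groups than the first three compounds could show, with no step yet beyond the scatter. Nothing available here accounts for this flatness, and no measurement bears on what lies behind it.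

The compounds shown leave open whether a methyl ester or a primary amide in place of the carboxyl group would also leave this assay flat, and whether a non-aromatic group such as a piperidine or a simple aminomethyl group at the same place would do so. They also leave open which group at this position, if any, would produce a step beyond the scatter.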